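Removing a Bromine and the Expected Effect on Cell Tolerance

The source may hold more compounds than are shown below. What is called first, only, known or untested is meant among the compounds shown, and "the series" means these compounds.

Within the data shown here, compound 2 `N/C(=N/NC(CC(=O)c1ccc(-n2ccnc2)cc1)c1ccc(Br)cc1)c1ccccn1` is the better tolerated of the two compounds measured so far: in an ADME assay on Vero cells (Chlorocebus sabaeus) for cytotoxicity, read by MTT assay, with a stated time of 72 h (a higher number here means that more compound is tolerated, a lower number that less compound is tolerated), compound 2 gives 298000 nM. Among the measured compounds shown here, the only other measured compound, compound 1 `N/C(=N/NC(CC(=O)c1ccc(-n2ccnc2)cc1)c1cccc(Cl)c1)c1ccccn1`, gives 68600 nM in this assay. For the measured compounds named here, the single measured step, a 4.3-fold higher number from compound 1 to compound 2 (0.64 log units; beyond the scatter), shows that changing the halogen-bearing ring moves the number beyond the scatter. Compound 3 `N/C(=N/NC(CC(=O)c1ccc(-n2ccnc2)cc1)c1ccccc1)c1ccccn1` is not yet measured. Its difference from compound 2 is hydrogen in place of bromo on an aromatic carbon. Going by the values given here, no measured step removes a halogen outright, so the step from compound 1 to compound 2 bears on it only loosely, showing that this ring matters by a modest amount. The number for compound 3 is therefore expected to fall somewhat, with wide uncertainty. The estimated step for compound 3 is a 1.7-fold lower number from compound 2 to compound 3 (0.22 log units; within the scatter). Compound 3 is estimated at 180000 nM, with a range from 60000 nM to 550000 nM.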

Compound 3, half-maximal cytotoxic concentration: 63500 nM
For compound 3 the middle estimate is 2.8-fold (0.45 log units) above the measured one, within the range that was stated.
By their numbers in this assay, from the lowest: compounds 3 and 1 (each within the scatter of the next); then compound 2.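

In this assay, the bromo group on this aromatic carbon now proves to matter by itself: hydrogen in its place gives a 4.7-fold lower number from compound 2 to compound 3 (0.67 log units; beyond the scatter). A halogen on the ring does not always go with a higher number, however, since hydrogen in place of chloro gives a 1.1-fold lower number from compound 1 to compound 3 (0.03 log units; within the scatter), and compound 1 therefore goes against any general halogen rule. Nothing available explains why the bromo group in compound 2 makes this difference.

The compounds shown change both the halogen and its place together, so they leave open whether bromine itself or its place on the ring is what counts, and a 4-chlorophenyl group would separate the two. As far as these compounds go, it also remains open whether a non-halogen group in that place, such as an amine or a methoxy group, would behave like bromo or like hydrogen.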